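Fluorine Removed from an Alkoxy Chain: Expectation for Compound 4

This account rests on a few compounds, and the source may have more. Where it says the series, first, only, none or still open, it means among the compounds named here.

Three compounds were measured in a functional assay on CHO cells for antagonist activity at sphingosine 1-phosphate receptor 2 (Homo sapiens), read by GTPgammaS binding; on this read-out higher numbers stand for weaker inhibition and lower numbers for stronger inhibition. Compound 1 `CCn1nc(CC(=O)Nc2ccc(OC(F)(F)F)c(Cl)c2)c2ccccc2c1=O` gives 473 nM, compound 2 `CCOc1cc2nn(Cc3nn(CC(=O)O)c(=O)c4ccccc34)cc2cc1Cl` gives 113 nM, and compound 3 `O=C(O)Cn1nc(Cc2nc3cc(Cl)c(OCC(F)F)cc3[nH]2)c2ccccc2c1=O` gives 15 nM. Compound 3 therefore stands lowest of the three, both gaps lying beyond the scatter, which makes it the most potent of the set. Compound 4 `CCOc1cc2[nH]c(Cc3nn(CC(=O)O)c(=O)c4ccccc34)nc2cc1Cl` differs from compound 3 in one place only: methyl in place of difluoromethyl on a saturated chain carbon bound to an oxygen on an aromatic ring. No pair of measured compounds differs in this place alone, so the size of this step cannot be read from any shown step. The step of a 1.7-fold higher number from compound 3 to compound 4 (0.22 log units; within the scatter) is expected to be small, at most a modest rise in the number. The estimate for compound 4 in this assay is 25 nM, within a range from 8 nM to 80 nM.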

Compound 4, half-maximal inhibitory concentration in the sphingosine 1-phosphate receptor 2 assay: 109 nM
Compound 4: the middle estimate sits 4.4-fold (0.64 log units) below what was measured; the measured number lies above the stated range.
By their numbers in the sphingosine 1-phosphate receptor 2 assay, from the lowest: compound 3; then compounds 4 and 2 (each within the scatter of the next); then compound 1.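

Among the compounds shown here, in the sphingosine 1-phosphate receptor 2 assay, the step from difluoromethyl to methyl gives a 7.3-fold higher number from compound 3 to compound 4 (0.86 log units; beyond the scatter), so this place on the saturated chain carbon bound to an oxygen on an aromatic ring clearly affects the number, which the earlier compounds could not show. In a physicochemical assay for solubility, measured as thermodynamic solubility, at pH 7.4 (on this read-out lower numbers stand for lower solubility and higher numbers for higher solubility), compound 4 gives 917 ug/mL. Compound 3 gives > 1000 ug/mL, which is a limit of the assay and not a number.

The compounds shown leave open how the number moves with other groups here, such as trifluoroethyl, a longer chain or an amine. Going by these compounds, whether the effect of this change holds on other cores also remains open.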